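Sulfonyl aryl variation on the piperidine amide series

The source may hold more compounds than are shown below. What is called first, only, known or untested is meant among the compounds shown, and "the series" means these compounds.

Working notes on the set. Among the measured compounds shown here, compound 1 `CCN(Cc1ccccc1)C(=O)C1CCN(S(=O)(=O)c2cccc3c2OCCO3)CC1` is the one member with a number in a functional assay on CHO cells for positive allosteric modulation of muscarinic acetylcholine receptor M5 (Homo sapiens), read by calcium flux; on this read-out lower numbers stand for smaller maximal responses and higher numbers for larger maximal responses: compound 1 gives 53% in that read-out. Compound 2 `CCN(Cc1ccccc1)C(=O)C1CCN(S(=O)(=O)c2c(C)noc2C)CC1` carries another group on the sulfonyl sulfur, and in this assay compound 2 gives "not determined" (no result reported) as its entry. Compound 3 `CCN(Cc1ccccc1)C(=O)C1CCN(S(=O)(=O)c2cccnc2)CC1` likewise has no single number in this assay; compound 3 gives "not determined" (no result reported) there. So compound 3 stands without a number, as does one further member, compound 2, and the measured data do not show how the group on the sulfonyl sulfur moves the maximal response.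

Compound 4 `CCN(Cc1ccccc1)C(=O)C1CCN(S(=O)(=O)c2ccc3cccnc3c2)CC1` differs from compound 3 in one place: quinolin-7-yl in place of pyridin-3-yl on a sulfonyl sulfur is the whole of the change.

For the measured compounds named here, no step between measured compounds exists, so neither size nor direction of the move from compound 3 to compound 4 in this assay can be anchored on a measured pair. Going by the values given here, the only number available is that of compound 1 at 53% in the series. On that basis the maximal response of compound 4 is expected to lie in the same region, with no change beyond the usual scatter assumed in either direction and with wide uncertainty. Compound 4 is expected to reach about 50% in this assay, within an estimated range from 20% to 85% in that read-out.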

Compound 4, largest response reached (reported as percent of maximum), in percent of the reference or control that the assay uses: 66%
The estimate for compound 4 lay 16 percentage points below the measured number; the measured number falls inside the stated range.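

The sulfonyl sulfur now has its first measured pair: in this assay, quinolin-7-yl in place of 2,3-dihydro-1,4-benzodioxin-5-yl gives a number 13 percentage points higher from compound 1 to compound 4 (beyond the scatter), so the maximal response does move with the group at this place while the rest of the structure stays the same. The step from compound 3 to compound 4 and any step involving compound 2 cannot be read, since neither compound 3 nor compound 2 has a number, which leaves the effect of adding the carbon-only aromatic ring to pyridin-3-yl unknown. No supporting data bear on why quinolin-7-yl gives the larger maximal response in this pair.

The compounds shown do not settle whether the ring nitrogen of quinolin-7-yl matters, a question that naphthalen-2-yl, with carbon in its place, would address directly. Also open, going by these compounds, is how far the response depends on having two fused rings on the sulfonyl sulfur, which a plain phenyl or a cyclohexyl group there would help to define.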